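One added methyl on an ethoxymethyl side chain

This account rests on a few compounds, and the source may have more. Where it says the series, first, only, none or still open, it means among the compounds named here.

compound 1 `Oc1c(CN2CCCCC2)ccc2cccnc12`: 2690 nM; 2750 nM (2 entries)
compound 2 `CCOCc1cc(CN2CCCCC2)c(O)c2ncccc12`: 7080 nM
compound 3 `CC(C)OCc1cc(CN2CCCCC2)c(O)c2ncccc12`: not yet measured

For the measured compounds named here, in a functional assay on MES-SA/Dx5 cells (Homo sapiens) for inhibition, with a stated time of 72 h, in the presence of a further agent that is not named here (a higher number here means a weaker inhibitor, a lower number a stronger inhibitor), compound 2 gives 7080 nM, its only single number there, and one further entry gives no single number. Its value is the higher of the two measured compounds, as compound 1 gives 2690 nM; 2750 nM (2 entries). Compound 3 turns ethoxymethyl into isopropoxymethyl, with methyl in place of hydrogen on a saturated chain carbon bound to an oxygen on a saturated carbon and a saturated chain carbon. Going by the values given here, no measured pair shows this change, so only a small shift, none beyond the scatter, is expected: the estimated step is a 1.1-fold lower number from compound 2 to compound 3 (0.04 log units; within the scatter). Compound 3 is estimated at 6500 nM, with an expected range from 2800 nM to 15000 nM.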

Compound 3, half-maximal inhibitory concentration: 4370 nM
The estimate for compound 3 lay 1.5-fold (0.17 log units) above the measured number, within the range that was stated.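

In this assay, the first step measured on this side chain, ethoxymethyl to isopropoxymethyl, gives a 1.6-fold lower number from compound 2 to compound 3 (0.21 log units; within the scatter). This position therefore accepts the added methyl without a difference that can be told apart from the usual scatter. Repeat entries for one compound show how closely two readings can agree: the several entries of compound 1 in this assay, 2690 nM; 2750 nM (2 entries)

The compounds shown leave open whether a longer chain, an amine or a carboxylic acid at this position would move the number beyond the scatter.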